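Chain Length and Cytotoxicity in a Cyanoimino Series

This account rests on a few compounds, and the source may have more. Where it says the series, first, only, none or still open, it means among the compounds named here.

Compound 1 `N#C/N=C1\N(CCCCCCOc2ccc(Cl)cc2)C(=O)C(c2ccccc2)N1c1ccncc1` and compound 2 `N#C/N=C1\N(CCCCCCCOc2ccc(Cl)cc2)C(=O)C(c2ccccc2)N1c1ccncc1` share one core and differ only in that ((4-chlorophenoxy)methyl in place of 4-chlorophenoxy on a saturated chain carbon, six bonds along the chain from an amide-type nitrogen in a ring). In a functional assay on NUGC cells (stomach, Homo sapiens) for cytotoxicity (a lower number here means a stronger inhibitor, a higher number a weaker inhibitor), compound 1 gives 3340 nM, and compound 2 gives 3350 nM; the step is a 1.0-fold higher number from compound 1 to compound 2 (0.00 log units; within the scatter). Compound 3 `N#C/N=C1\N(CCCCCOc2ccc(Cl)cc2)C(=O)CCN1c1ccncc1` is built on a second core; the difference between the two cores is not broken down here. In this assay compound 3 gives 3120 nM, a value that sits within the scatter of both compound 1 and compound 2, so no order among the three can be read.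

Compound 4 `N#C/N=C1\N(CCCCCCOc2ccc(Cl)cc2)C(=O)CCN1c1ccncc1` has not yet been measured in this assay. It differs from compound 3 in that ((4-chlorophenoxy)methyl in place of 4-chlorophenoxy on a saturated chain carbon, five bonds along the chain from an amide-type nitrogen in a ring). For the measured compounds named here, this is the same kind of change as the one from compound 1 to compound 2, but the place is not identical: six bonds along the chain from an amide-type nitrogen in a ring in the first pair, five bonds in the second. Because a 1.0-fold higher number from compound 1 to compound 2 (0.00 log units; within the scatter) lies within the scatter, the expected step is a 1.0-fold higher number from compound 3 to compound 4 (0.01 log units; within the scatter). For compound 4 the estimate in this assay is 3200 nM, with a likely range from 1600 nM to 6400 nM.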

Compound 4, half-maximal inhibitory concentration: 288 nM
For compound 4 the middle estimate is 11-fold (1.05 log units) above the measured one, and the stated range ends above it.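

In this assay the change gives an 11-fold lower number from compound 3 to compound 4 (1.03 log units; beyond the scatter), a large step, whereas on the core of compound 1 the same change gives a 1.0-fold higher number from compound 1 to compound 2 (0.00 log units; within the scatter). The size of this step therefore did not carry from one core to the other: the same change on two cores in this assay, a 1.0-fold higher number (0.00 log units; within the scatter) from compound 1 to compound 2 and an 11-fold lower number (1.03 log units; beyond the scatter) from compound 3 to compound 4, 11-fold (1.04 log units) apart, beyond the scatter of two such steps

This does not show that the core alone sets the difference, since the place of the change also differs, six bonds along the chain from an amide-type nitrogen in a ring in one pair and five bonds in the other, and a single pair on each core gives no rule for the wider series. The compounds shown leave open how 2-(4-chlorophenoxy)ethyl in place of (4-chlorophenoxy)methyl would read on the core of compound 4, and thus whether a longer chain on that core would hold the gain or lose it. They also leave open whether an amine or a carboxylic acid in place of 4-chlorophenoxy would keep the number seen for compound 4.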